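Bromoacrylamide thiazolidinediones: chloro for trifluoromethyl on the benzyl ring

A few compounds are considered here, and "the series" means these few. Any claim that something is new, unique, unknown or untested is made for them only; others in the source may bear on it.

Compound 1 `C=C(Br)C(=O)Nc1ccc(/C=C2\SC(=O)N(Cc3ccc(Cl)cc3)C2=O)cc1` gives 3400 nM in a functional assay on L1210 cells (Mus musculus) for cytotoxicity, read by cell counting, with a stated time of 2 days; a lower number here means a stronger inhibitor, a higher number a weaker inhibitor; compound 2 `C=C(Br)C(=O)Nc1ccc(/C=C2\SC(=O)N(Cc3ccc(C(F)(F)F)cc3)C2=O)cc1` gives 12000 nM. The change chloro in place of trifluoromethyl on an aromatic carbon made a step of a 3.5-fold lower number from compound 2 to compound 1 (0.55 log units; beyond the scatter). Compound 3 `C=C(Br)C(=O)Nc1cccc(/C=C2\SC(=O)N(Cc3ccc(C(F)(F)F)cc3)C2=O)c1` carries the same substituent as compound 2 but on a different core; the difference between the two cores is not broken down here. In this assay compound 3 gives 720 nM, the lowest number of the three. Compound 4 `C=C(Br)C(=O)Nc1cccc(/C=C2\SC(=O)N(Cc3ccc(Cl)cc3)C2=O)c1` is not yet measured; it differs from compound 3 by chloro in place of trifluoromethyl on an aromatic carbon, the same change as that from compound 2 to compound 1. Going by the values given here, because a 3.5-fold lower number from compound 2 to compound 1 (0.55 log units; beyond the scatter) lowered the number on the other core, a step of similar size is expected here, a 2.9-fold lower number from compound 3 to compound 4 (0.46 log units; beyond the scatter), though only one earlier example supports it. Compound 4 is thus estimated at 250 nM, with the likely range 100 nM to 700 nM.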

Compound 4, half-maximal inhibitory concentration: 940 nM
For compound 4 the middle estimate is 3.8-fold (0.58 log units) below the measured one, and the stated range ends below it.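

On the second core, chloro in place of trifluoromethyl makes a 1.3-fold higher number from compound 3 to compound 4 (0.12 log units; within the scatter) in this assay and so does not repeat the lowering seen on the core of compound 1. The same change therefore behaves differently on the two cores: the same change on two cores in this assay, a 3.5-fold lower number (0.55 log units; beyond the scatter) from compound 2 to compound 1 and a 1.3-fold higher number (0.12 log units; within the scatter) from compound 3 to compound 4, 4.6-fold (0.66 log units) apart, beyond the scatter of two such steps

This shows that the step cannot be assumed to carry from one of these cores to the other, but with one pair per core it does not show which feature of the cores sets the gap, nor how the change behaves on any further core.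

Still open, from the compounds shown here alone, is whether a methoxy group, a nitrile or a carboxylic acid in the same place would separate the two cores. The unsubstituted benzyl ring also remains an open comparison on each core.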